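Aryl ether variation at the phenol oxygen: cytotoxicity notes

The source may hold more compounds than are shown below. What is called first, only, known or untested is meant among the compounds shown, and "the series" means these compounds.

Compound 2 `O=C(NCCNS(=O)(=O)c1ccc(-c2ccccc2O[C@H]2CC[C@@H](O)CC2)s1)Nc1cc(C(F)(F)F)cc(C(F)(F)F)c1` is the parent for this step. In an ADME assay on HEK-293T cells (Homo sapiens) for cytotoxicity, read by CCK-8 assay, with a stated time of 48 h (a lower number here means a stronger inhibitor, a higher number a weaker inhibitor), compound 2 gives 14100 nM, the highest of the two numbers that are known in this series, though its nearest neighbour compound 3 `O=S(=O)(NCCNC(=S)Nc1ccc(Cl)cc1)c1ccc(-c2ccccc2OCc2ccccc2)s1` gives 12100 nM and the gap between them lies within the scatter. Compound 1 `O=C(NCCNS(=O)(=O)c1ccc(-c2ccccc2OCc2cccc(O)c2)s1)Nc1cc(C(F)(F)F)cc(C(F)(F)F)c1` gives only a limit here, > 20000 nM. For the measured compounds named here, the one measured step, an at least 1.4-fold lower number from compound 1 to compound 2 (0.15 log units; that floor lies within the scatter), rests on that limit of > 20000 nM in this assay, at which 1 of the 3 values shown sits, and so its size is not a number; the floor of the step is within the scatter.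

Compound 4 `Nc1ccc(Oc2ccccc2-c2ccc(S(=O)(=O)NCCNC(=O)Nc3cc(C(F)(F)F)cc(C(F)(F)F)c3)s2)cc1` carries the next change on the same oxygen: 4-aminophenyl in place of 4-hydroxycyclohexyl on an oxygen on an aromatic ring. Going by the values given here, the only measured step at this position is the one from compound 1 to compound 2, and it tells little beyond its floor, so the expectation for this assay is a step of no clear size in either direction, with a real chance that compound 4 again returns only a limit. The expected step from compound 2 to compound 4 is therefore a 1.1-fold higher number from compound 2 to compound 4 (0.03 log units; within the scatter), within the scatter. For compound 4 the estimate in this assay is 15000 nM, with a range from 7000 nM to 30000 nM.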

Compound 4, half-maximal inhibitory concentration: > 20000 nM
Compound 4: only a limit was reported; the forecaster's own chance of this, stated with the estimate: 35%; middle value at least 1.3-fold (0.12 log units) from the limit.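

In this assay, on these data alone, 4-aminophenyl in place of 4-hydroxycyclohexyl on this oxygen gives an at least 1.4-fold higher number from compound 2 to compound 4 (0.15 log units; that floor lies within the scatter), so the size of the change remains unknown and only its direction is indicated. For the compounds shown here, this is the first case in which a nitrogen-bearing group sits at this position, and it shows that an aromatic ring carried directly on the oxygen, as in compound 4, does not bring a number into the readable range of the assay. The step between compound 1 and compound 4 cannot be read, and among the compounds differing only on this oxygen, compound 2 alone has a measured number, so the comparison at this position rests largely on a limit: the limit of > 20000 nM in this assay, at which 2 of the 4 values shown sit.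

As far as these compounds go, it remains open how far compound 1 and compound 4 actually lie from compound 2, since neither limit gives a size. A 4-aminocyclohexyl group or an unsubstituted phenyl group on the same oxygen would separate the effect of the amine from that of the ring, and a 4-carboxyphenyl group would test a different substituent on the same aromatic ring.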